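Swapping the amide aryl group in a phosphodiesterase inhibitor

The source may report more compounds than this note shows. Statements on the series, on what has been measured and on what is new or still open speak of the compounds shown alone.

Of the compounds shown here, two have been measured in an assay on isolated protein for inhibition of phosphodiesterase 4A (Sus scrofa); on this read-out lower numbers stand for stronger inhibition and higher numbers for weaker inhibition. Compound 1 `COc1ccc(C(=O)Nc2ccccc2SC)cc1OC1CCCC1` gives 1200 nM in this assay, the higher of the two numbers, so it is the weaker inhibitor of the pair. Compound 2 `COc1ccc(C(=O)Nc2c(Cl)cccc2Cl)cc1OC1CC2CCC1C2` gives 10 nM in this assay, a gap beyond the usual scatter; the two structures differ in more than one place, so their values can only be compared, not traced to a single change.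

The step to be followed leads from compound 1 to compound 3 `COc1ccc(C(=O)Nc2c(C)nsc2C#N)cc1OC1CCCC1`, which has not yet been measured. The change is 5-cyano-3-methyl-1,2-thiazol-4-yl in place of 2-(methylsulfanyl)phenyl on an amide-type nitrogen. The shared core stays untouched. Within the data shown here, no single-change step between measured compounds exists to guide this expectation, so it rests on the two values alone. With compound 2 at 10 nM showing that a different group on the amide nitrogen can sit far lower than compound 1, the step of a 10-fold lower number from compound 1 to compound 3 (1.00 log units; beyond the scatter) is expected to bring a moderate gain beyond the scatter. Compound 3 is estimated at 120 nM, in a range from 25 nM to 600 nM.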

Compound 3, half-maximal inhibitory concentration: 200 nM
Compound 3: the middle estimate sits 1.7-fold (0.22 log units) below what was measured, within the range that was stated.
By their numbers in this assay, from the lowest: compound 2; then compound 3; then compound 1.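

Among these compounds, this is the first change in the set that can be traced to one place, so a difference in this assay can now be tied to the group on the amide-type nitrogen while the shared core stays untouched. Putting 5-cyano-3-methyl-1,2-thiazol-4-yl in place of 2-(methylsulfanyl)phenyl gives a 6.0-fold lower number from compound 1 to compound 3 (0.78 log units; beyond the scatter) and shows that this position accepts a five-membered aromatic ring with 2 hetero atoms instead of a six-membered aromatic ring of carbon only, with a gain in inhibition. No measurement at hand explains the gain, and since the ring, its hetero atoms, the nitrile and the methyl group all enter together, the step cannot be divided among them.

The compounds shown leave open which part of the new group carries the step, a question that a close analogue with a carboxylic acid or an amine in place of the nitrile could help to answer. They also leave open whether the same swap would give a similar step on a different core, as one pair of compounds cannot show how far the result extends.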